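Pyridin-4-yl in Place of Pyridin-3-yl: Compound 3 Expected

The source may hold more compounds than are shown below. What is called first, only, known or untested is meant among the compounds shown, and "the series" means these compounds.

Measured compounds:
compound 1, `COc1ccc(C(=O)/C=C/c2cn(-c3ccccc3)nc2-c2cccnc2)cc1OC`, 3100 nM in a functional assay on Huh-7 cells (Homo sapiens) for inhibition, read by sulforhodamine B assay, with a stated time of 72 h; on this read-out lower numbers stand for stronger inhibition and higher numbers for weaker inhibition
compound 2, `COc1ccc(C(=O)/C=C/c2cn(-c3ccccc3)nc2-c2cccnc2)c(OC)c1`, 2400 nM in this assay

Compound 1 gives the higher of the two numbers shown, and its nearest neighbour is compound 2, the gap being a 1.3-fold lower number from compound 1 to compound 2 (0.11 log units; within the scatter). That single measured step concerns the dimethoxyphenyl on the carbonyl carbon and stays within the scatter of repeated measurements.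

Compound 3, `COc1ccc(C(=O)/C=C/c2cn(-c3ccccc3)nc2-c2ccncc2)cc1OC`, differs from compound 1 in another part of the shared core: pyridin-4-yl in place of pyridin-3-yl on an aromatic carbon. Among the measured compounds shown here, no measured step touches this pyridinyl group, so the only guide is that the one change tried so far, a 1.3-fold lower number from compound 1 to compound 2 (0.11 log units; within the scatter), moved the number by less than the scatter. There is therefore no evidence for a step beyond the scatter in this assay in either direction, and the number for compound 3 is expected to sit close to that of compound 1, with a wide allowance for the unknown.

Compound 3 is accordingly estimated at 3000 nM, within a range from 1200 nM to 8000 nM. This estimate amounts to an expected step of a 1.0-fold lower number from compound 1 to compound 3 (0.01 log units; within the scatter).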

Compound 3, half-maximal inhibitory concentration: 2000 nM
Beside the measured number, compound 3's estimate is 1.5-fold (0.18 log units) above it, and the stated range covers the measured number.
By their numbers in this assay, from the lowest: compounds 3, 2 and 1 (each within the scatter of the next).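

Replacing pyridin-3-yl with pyridin-4-yl, on an aromatic carbon of a five-membered aromatic ring with 2 nitrogen, gives in this assay a 1.6-fold lower number from compound 1 to compound 3 (0.19 log units; within the scatter), so this site of the shared core now has a measured step of its own, and that step stays inside the scatter. The two groups carry the same atoms, joined differently, which shows that in this one pair, with the 3,4-dimethoxyphenyl on the carbonyl carbon, this rearrangement of the pyridinyl group does not separate the numbers beyond what repeated measurements would. No measurement is available that bears on the reason for this result.

The compounds shown leave open whether a larger change at this site, such as a plain phenyl, pyridin-2-yl, or a pyridinyl group bearing an amine or a carboxylic acid, would move the number beyond the scatter. Among the compounds shown here, they also leave open whether pyridin-4-yl would give a similar result alongside the 2,4-dimethoxyphenyl of compound 2, since this change has been read against only a single partner group.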